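Trifluoromethyl for methoxy on the para-substituted phenyl

The source may report more compounds than this note shows. Statements on the series, on what has been measured and on what is new or still open speak of the compounds shown alone.

Within the data shown here, in an assay on microsomes for inhibition of acyl-CoA:cholesterol acyltransferase (Oryctolagus cuniculus) (a higher number here means a weaker inhibitor, a lower number a stronger inhibitor), compound 2 (`COc1ccc(C2(CNC(=O)Nc3c(C(C)C)cccc3C(C)C)CCCC2)cc1`) gives 31 nM, the lowest of the two numbers measured so far; its nearest neighbour is compound 1 (`CC(C)c1cccc(C(C)C)c1NC(=O)NCC1(c2ccc(C(C)(C)C)cc2)CCCC1`), which in this assay gives 63 nM. Among the measured compounds shown here, the one measured step, a 2.0-fold lower number from compound 1 to compound 2 (0.31 log units; beyond the scatter), runs from the same series and shows a modest gain when a methoxy replaces a tert-butyl at that position. Compound 3 (`CC(C)c1cccc(C(C)C)c1NC(=O)NCC1(c2ccc(C(F)(F)F)cc2)CCCC1`) carries the change (trifluoromethyl in place of methoxy on an aromatic carbon). For the measured compounds named here, no measured step exchanges methoxy for trifluoromethyl, so the only guide is that the tert-butyl-to-methoxy step was modest; both measured values lie close together. For compound 3 the step of a 1.5-fold higher number from compound 2 to compound 3 (0.16 log units; within the scatter) is therefore expected to stay within the scatter or to be a small rise. Compound 3 is estimated at 45 nM, with a range from 20 nM to 110 nM.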

Compound 3, half-maximal inhibitory concentration: 66 nM
Compound 3: the middle estimate sits 1.5-fold (0.17 log units) below what was measured; low and high end bracket the measured number.
By their numbers in this assay, from the lowest: compound 2; then compounds 1 and 3 (each within the scatter of the next).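

With trifluoromethyl at this position, this assay shows a 2.1-fold higher number from compound 2 to compound 3 (0.33 log units; beyond the scatter) and so the lower number of compound 2 holds against a second group as well as against tert-butyl. Trifluoromethyl and tert-butyl are not separated here, as a 1.0-fold higher number from compound 1 to compound 3 (0.02 log units; within the scatter) leaves the two compounds within the scatter of each other. Of the three groups, methoxy alone therefore stands apart, although no evidence is available on what lies behind this difference.

The three compounds leave open whether the lower number is particular to methoxy or would also be seen with ethoxy, hydroxy or an amine at this position. They also leave open whether the same order of groups would hold if another part of the shared core were changed.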